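Chloro for Nitro on a Weak Kynurenine Transaminase Inhibitor

The compounds below may be only part of what the source reports. "The series", "measured", "known", "first", "only" and "open" are said of these compounds alone.

For the measured compounds named here, compound 1 `O=C(O)CCc1c(C(=O)O)[nH]c2ccc([N+](=O)[O-])cc12` gives 666000 nM in an assay on isolated protein for inhibition of kynurenine--oxoglutarate transaminase 1 (Homo sapiens), read by HPLC, with a stated time of 20 min (on this read-out lower numbers stand for stronger inhibition and higher numbers for weaker inhibition), the higher of the two numbers measured so far. Compound 2 `CCOC(=O)/C(CCCC(=O)O)=N\Nc1ccc(OC)cc1`, built on a different core, gives 43000 nM in this assay, a lower number that lies beyond the scatter. Compound 3 `O=C(O)CCc1c(C(=O)O)[nH]c2ccc(Cl)cc12` differs from compound 1 in one place: chloro in place of nitro on an aromatic carbon. Going by the values given here, no measured pair shows this change, so nothing here tells its effect. The step of a 1.5-fold lower number from compound 1 to compound 3 (0.17 log units; within the scatter) is expected to stay within the scatter, in no clear direction. Compound 3 is therefore estimated at 450000 nM, in a range from 120000 nM to 1800000 nM.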

Compound 3, half-maximal inhibitory concentration: 293000 nM
Compound 3: the middle estimate sits 1.5-fold (0.19 log units) above what was measured; the range from low to high includes it.
By their numbers in this assay, from the lowest: compound 2; then compound 3; then compound 1.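

In this assay, chloro in place of nitro on this aromatic carbon gives a 2.3-fold lower number from compound 1 to compound 3 (0.36 log units; beyond the scatter), a modest step, so what sits at this position of the shared core does affect the read-out. In this one pair, the hydrogen-bond acceptors of nitro can go without any loss of inhibition. Nothing measured here accounts for the step.

As far as these compounds go, whether an amine or a bromo on the same carbon would give a lower number remains open. So does whether replacing either carboxylic acid of the core would change the step.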